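Isopropyl in Place of Methyl on a Ring Amine Nitrogen

The source may report more compounds than this note shows. Statements on the series, on what has been measured and on what is new or still open speak of the compounds shown alone.

Of the compounds shown here, three with a shared core have been measured in a functional assay on HeLa cells for agonist activity at 5-hydroxytryptamine receptor 6 (Homo sapiens), read by cAMP accumulation and immunoassay; a higher number here means a larger maximal response, a lower number a smaller maximal response. Compound 1 `O=S(=O)(c1cccc(F)c1)c1cn(C2CCNC2)c2ncccc12` gives 44%. Compound 2 `CN1CCC(n2cc(S(=O)(=O)c3cccc(F)c3)c3cccnc32)C1` gives 54%. Compound 3 `CN1CCCC(n2cc(S(=O)(=O)c3cccc(F)c3)c3cccnc32)C1` gives 75%, the highest of the three numbers, with compound 2 nearest and compound 1 furthest. The steps of a number 21 percentage points higher from compound 2 to compound 3 (beyond the scatter) and a number 31 percentage points higher from compound 1 to compound 3 (beyond the scatter) both lie beyond the scatter, whereas the step of a number 10 percentage points higher from compound 1 to compound 2 (within the scatter) stays within it.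

Compound 4 `CC(C)N1CCCC(n2cc(S(=O)(=O)c3cccc(F)c3)c3cccnc32)C1` differs from compound 3 by isopropyl in place of methyl on an amine nitrogen in a ring. For the measured compounds named here, the only measured step that touches the same amine nitrogen in a ring is a number 10 percentage points higher from compound 1 to compound 2 (within the scatter), and it stayed within the scatter. No measured compound carries an isopropyl group, so nothing shown speaks to that group directly. The reviewer therefore expects the step of a number 3 percentage points lower from compound 3 to compound 4 (within the scatter) in this assay to stay within the scatter, with no clear direction. Compound 4 is estimated at 72%, with a range from 55% to 90%.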

Compound 4, largest response reached (Emax), in percent of the reference or control that the assay uses: 67%
Beside the measured number, compound 4's estimate is 5 percentage points above it; the measured number falls inside the stated range.
By their numbers in this assay, from the lowest: compounds 1 and 2 (each within the scatter of the next); then compounds 4 and 3 (each within the scatter of the next).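

The step of a number 8 percentage points lower from compound 3 to compound 4 (within the scatter) in this assay shows that, on this amine nitrogen of a six-membered non-aromatic ring, a group larger than methyl can enter without a change beyond the scatter. The steps of a number 13 percentage points higher from compound 2 to compound 4 (beyond the scatter) and a number 23 percentage points higher from compound 1 to compound 4 (beyond the scatter) both lie beyond the scatter, so 1-isopropylpiperidin-3-yl, like 1-methylpiperidin-3-yl, keeps the response clear of the 1-methylpyrrolidin-3-yl and pyrrolidin-3-yl compounds. Nothing measured here accounts for this result.

The compounds shown leave open how the response would run with a plain hydrogen on the same nitrogen of the six-membered ring, or with a longer chain, a cyclopropyl group or a benzyl group there. They also leave open whether isopropyl on the nitrogen of the pyrrolidin-3-yl group would behave as it does here.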